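Adding a bromine to the thiophene of compound 2

This account rests on a few compounds, and the source may have more. Where it says the series, first, only, none or still open, it means among the compounds named here.

Measured compounds:
- compound 1, `O=C(/C=C/c1ccc(N2CCCCC2)cc1)c1ccc(Br)s1`: 52800 nM
- compound 2, `c1csc(C2=NNC(c3ccc(N4CCCCC4)cc3)C2)c1`: 6900 nM

Of the compounds shown here, two have so far been tested in an ADME assay on CCRF-CEM cells (Homo sapiens) for cytotoxicity, with a stated time of 5 days; a lower number here means a stronger inhibitor, a higher number a weaker inhibitor. Compound 1 is `O=C(/C=C/c1ccc(N2CCCCC2)cc1)c1ccc(Br)s1` and in this assay compound 1 gives 52800 nM. Compound 2 is `c1csc(C2=NNC(c3ccc(N4CCCCC4)cc3)C2)c1` and in this assay compound 2 gives 6900 nM. Of these two numbers, compound 2 has the lower one, and its distance from compound 1 lies beyond the usual scatter, so compound 2 is the stronger inhibitor of the pair. No single-point change between these two has been worked out, since they differ in more than one place.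

The next compound, compound 3, is `Brc1ccsc1C1=NNC(c2ccc(N3CCCCC3)cc2)C1`. Its difference from compound 2 is one change: bromo in place of hydrogen on an aromatic carbon. For the measured compounds named here, nothing measured so far shows what this particular change does on the shared core of compound 2 and compound 3. The step from compound 2 to compound 3 in this assay is therefore expected to be small, with no clear direction, and most likely within the scatter; the expected size is a 1.3-fold lower number from compound 2 to compound 3 (0.10 log units; within the scatter). Compound 3 is expected to give about 5500 nM in this assay, with a likely range from 1800 nM to 17000 nM.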

Compound 3, half-maximal inhibitory concentration: 31600 nM
The estimate for compound 3 lay 5.7-fold (0.76 log units) below the measured number, and the stated range ends below it.
By their numbers in this assay, from the lowest: compound 2; then compounds 3 and 1 (each within the scatter of the next).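

In this assay, for the compounds shown here, this is the first comparison that isolates a single change on the shared core, and it shows that this position is sensitive to substitution. Replacing thiophen-2-yl with 3-bromothiophen-2-yl gives a 4.6-fold higher number from compound 2 to compound 3 (0.66 log units; beyond the scatter), so adding one bromine atom weakens inhibition by more than the usual variation between repeated measurements. The effect applies to this one aromatic carbon, next to the ring atom that bears a large group and two ring bonds from the ring sulfur, and there is no evidence available to explain it.

The compounds shown cannot tell whether this loss is specific to bromo or would also occur with another group on the same carbon, such as chloro, methyl or methoxy. They also leave open whether bromo on a different carbon of the five-membered ring would produce a step of similar size and direction, or whether a group such as an amine or a carboxylic acid at this position would behave differently.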